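Swapping the Aryl Group on a Triazole Ester

The source may hold more compounds than are shown below. What is called first, only, known or untested is meant among the compounds shown, and "the series" means these compounds.

Compound 1 `C/C(=C\CC/C(C)=C/CC[C@@H]1[C@@]2(C)CCC(=O)C(C)(C)[C@H]2CC[C@@]1(C)O)CC/C=C(\C)C(=O)OCc1cn(-c2ccccc2Br)nn1`: > 150000 nM
Compound 2 `C/C(=C\CC/C(C)=C/CC[C@@H]1[C@@]2(C)CCC(=O)C(C)(C)[C@H]2CC[C@@]1(C)O)CC/C=C(\C)C(=O)OCc1cn(-c2cccc(Cl)c2)nn1`: 103000 nM

On these data alone, in a functional assay on MDA-MB-231 cells (Homo sapiens) for antiproliferative activity, read by MTT assay, with a stated time of 48 h (a lower number here means a stronger inhibitor, a higher number a weaker inhibitor), compound 1 reaches only the limit of the assay, > 150000 nM, so where it truly stands is unknown (the limit of > 150000 nM in this assay, at which 1 of the 2 values shown sits). Compound 2 gives 103000 nM. Compound 3 `C/C(=C\CC/C(C)=C/CC[C@@H]1[C@@]2(C)CCC(=O)C(C)(C)[C@H]2CC[C@@]1(C)O)CC/C=C(\C)C(=O)OCc1cn(-c2cccc(O)c2)nn1` differs from compound 1 by 3-hydroxyphenyl in place of 2-bromophenyl on an aromatic nitrogen. Going by the values given here, the single measured step that bears on this change, another swap of the aryl group on the same ring nitrogen, is an at least 1.4-fold lower number from compound 1 to compound 2 (0.16 log units; that floor lies within the scatter), a floor that lies within the scatter. Compound 3 is therefore expected to shift only slightly, an at least 1.2-fold lower number from compound 1 to compound 3 (0.09 log units; that floor lies within the scatter). Compound 3 is estimated at 120000 nM, between 55000 nM and 260000 nM.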

Compound 3, half-maximal inhibitory concentration: 139000 nM
Beside the measured number, compound 3's estimate is 1.2-fold (0.06 log units) below it, and the stated range covers the measured number.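

In this assay, hydroxy in place of chloro gives a 1.3-fold higher number from compound 2 to compound 3 (0.13 log units; within the scatter), so at this position on the ring, the 3-hydroxyphenyl group, with its hydrogen-bond donor, cannot be told apart from the 3-chlorophenyl group. The change from the 2-bromophenyl group gives only a floor, an at least 1.0-fold lower number from compound 1 to compound 3 (0.03 log units; that floor lies within the scatter), which says little about its true size. Compound 1 gives a limit and not a number: the limit of > 150000 nM in this assay, at which 1 of the 3 values shown sits.

On these data alone, whether an amine or a carboxylic acid on the aryl group would move the number beyond the scatter stays open.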